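A few compounds are considered here, and "the series" means these few. Any claim that something is new, unique, unknown or untested is made for them only; others in the source may bear on it.

Measured so far:
- compound 1 `Cc1cc(-c2ccc(C(=O)c3cc(F)cc(O)c3C)s2)cc(C)c1O`: 6 nM
- compound 2 `Cc1cc(-c2ccc(C(=O)c3cccc(O)c3C)s2)cc(C)c1O`: 899 nM

In an assay for inhibition of 17-beta-hydroxysteroid dehydrogenase type 1 (Homo sapiens), read by HPLC, in the presence of a further agent that is not named here (a higher number here means a weaker inhibitor, a lower number a stronger inhibitor), compound 1 gives 6 nM and stands at the lowest of the two numbers; its nearest neighbour is compound 2, which in this assay gives 899 nM. Among the measured compounds shown here, the single measured step, a 150-fold higher number from compound 1 to compound 2 (2.18 log units; beyond the scatter), is a large one and lies well beyond the scatter: it consists of hydrogen in place of fluoro on an aromatic carbon.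

Compound 3 `Cc1cc(-c2ccc(C(=O)c3cc(F)c(F)c(O)c3C)s2)cc(C)c1O` is not yet measured. It differs from compound 1 by fluoro in place of hydrogen on an aromatic carbon. The measured step bears on this only indirectly: it shows that the fluoro already present in compound 1 is tied to a large part of its potency, but it does not show what a second fluoro at the neighbouring position does. For the measured compounds named here, no pair among the measured compounds probes such an addition. The expectation is therefore conservative: no step beyond the scatter is anticipated in this assay, with the existing fluoro retained. Compound 3 is expected to give about 7 nM, within 2 nM to 25 nM, which is estimated as a step of a 1.2-fold higher number from compound 1 to compound 3 (0.07 log units; within the scatter).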

Compound 3, half-maximal inhibitory concentration in the 17-beta-hydroxysteroid dehydrogenase type 1 assay: 44 nM
For compound 3 the middle estimate is 6.3-fold (0.80 log units) below the measured one, outside the stated range (above it).
By their numbers in the 17-beta-hydroxysteroid dehydrogenase type 1 assay, from the lowest: compound 1; then compound 3; then compound 2.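

In the 17-beta-hydroxysteroid dehydrogenase type 1 assay, the aromatic carbon ortho to a fluoro group and ortho to a hydroxy group does not tolerate substitution without consequence: fluoro in place of hydrogen there gives a 7.3-fold higher number from compound 1 to compound 3 (0.87 log units; beyond the scatter). The earlier pair showed only what removing the fluoro of compound 1 does in the 17-beta-hydroxysteroid dehydrogenase type 1 assay, namely a 150-fold higher number from compound 1 to compound 2 (2.18 log units; beyond the scatter), whereas this result shows that a second fluoro on the same ring weakens inhibition rather than adding to the potency of compound 1, though by a smaller step. In a physicochemical assay for solubility, in phosphate buffer, with a stated time of 24 h, at pH 7.2 (a lower number here means a less soluble compound, a higher number a more soluble compound), compound 1 gives 100000 nM and compound 3 gives 15000 nM. The same addition thus also comes with a drop in the physicochemical assay, again beyond the scatter, leaving compound 3 behind compound 1 on both read-outs: the measured solubility of compound 1, 100000 nM, and of compound 3, 15000 nM, a 6.7-fold lower number (0.82 log units; beyond the scatter)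

With only hydrogen and fluoro shown at this carbon, it remains open whether either shift is specific to fluoro or would follow from any substituent there, a question that a chloro, methoxy or amine group at the same place could address. Going by these compounds, it also remains open whether the shifts in inhibition and solubility are linked or simply occur together in this one pair.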